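Swapping a methoxy for methylsulfanyl on the benzyl ring

The source may hold more compounds than are shown below. What is called first, only, known or untested is meant among the compounds shown, and "the series" means these compounds.

Measured compounds:
compound 1 `COc1ccc(CNc2nc([Se]C)nc3ccccc23)cc1`: 33000 nM
compound 2 `COc1ccc(CNc2nc(SC)nc3ccccc23)cc1`: 93700 nM

In a functional assay on HTB-54 cells (Homo sapiens) for cytotoxicity, read by MTT assay, with a stated time of 72 h (a lower number here means a stronger inhibitor of growth, a higher number a weaker inhibitor of growth), compound 1 gives the lowest of the two numbers; the change to compound 2 gave a 2.8-fold higher number from compound 1 to compound 2 (0.45 log units; beyond the scatter), and that change sits on the shared core, not on the benzyl ring. Compound 3 `CSc1ccc(CNc2nc([Se]C)nc3ccccc23)cc1` differs from compound 1 by methylsulfanyl in place of methoxy on an aromatic carbon. Going by the values given here, no measured step covers this change, so nothing here points in either direction. Compound 3 is therefore expected to land close to compound 1, with a 1.1-fold lower number from compound 1 to compound 3 (0.04 log units; within the scatter) estimated within the scatter. The estimate for compound 3 is 30000 nM, with a range from 12000 nM to 80000 nM.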

Compound 3, concentration for 50% growth inhibition: 37900 nM
Compound 3: the middle estimate sits 1.3-fold (0.10 log units) below what was measured; the measured number falls inside the stated range.
By their numbers in this assay, from the lowest: compounds 1 and 3 (each within the scatter of the next); then compound 2.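

In this assay, methylsulfanyl in place of methoxy on the benzyl ring, para to a large group, gives a 1.1-fold higher number from compound 1 to compound 3 (0.06 log units; within the scatter). This position therefore accepts the swap with no readable change, unlike the earlier change on the shared core, a 2.8-fold higher number from compound 1 to compound 2 (0.45 log units; beyond the scatter). No measurement at hand offers an explanation for this result.

From the compounds shown here alone, whether this position would accept a very different group, such as an amine, a carboxylic acid or a longer chain, stays open. So does whether the same swap would read alike on compound 2, with sulfur rather than selenium on the core.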